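The compounds below may be only part of what the source reports. "The series", "measured", "known", "first", "only" and "open" are said of these compounds alone.

Measured so far in a functional assay on THP-1 cells (Homo sapiens) for inhibition, read by sulforhodamine B assay, tested at 10 uM; a lower number here means less inhibition of growth, a higher number more inhibition of growth at the concentration tested:

Compound 1 `COc1cc(C2CC(c3ccc(OCc4cn(Cc5ccc([N+](=O)[O-])cc5)nn4)cc3)=NN2C(C)=O)ccc1Oc1cn(Cc2ccc([N+](=O)[O-])cc2)nn1`: 0%
Compound 2 `COc1cc(C2CC(c3ccc([N+](=O)[O-])cc3)=NN2C(C)=O)ccc1OCc1cn(Cc2ccc([N+](=O)[O-])cc2)nn1`: 7%
Compound 3 `COc1cc(C2CC(c3ccccc3)=NN2C(C)=O)ccc1OCc1cn(Cc2ccc([N+](=O)[O-])cc2)nn1`: 0%

Among the measured compounds shown here, all three numbers fall within the usual scatter of one another, so no measured compound can be set apart from the others: compound 2 gives 7% in this assay, a number that is separated from compound 1 and from compound 3 by less than the scatter of repeated measurements. The compound now under consideration is compound 4 `COc1ccc(C2=NN(C(C)=O)C(c3ccc(OCc4cn(Cc5ccc([N+](=O)[O-])cc5)nn4)c(OC)c3)C2)cc1`. It differs from compound 2 in one place: methoxy in place of nitro on an aromatic carbon.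

For the measured compounds named here, one measured step bears on this change. Going from compound 2 to compound 3 also removes the nitro group from the same aromatic carbon, putting hydrogen in its place, and this gave a number 7 percentage points lower from compound 2 to compound 3 (within the scatter). Since that removal left the number where it was, putting methoxy in place of nitro is expected to do the same, with no step beyond the scatter in this assay. Compound 4 is therefore expected to show a number 4 percentage points lower from compound 2 to compound 4 (within the scatter). The estimate for compound 4 is 3%, between 0% and 15%.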

Compound 4, percent growth inhibition at one concentration: 8%
For compound 4 the middle estimate is 5 percentage points below the measured one, and the stated range covers the measured number.
By their numbers in this assay, from the lowest: compounds 1, 3, 2 and 4 (each within the scatter of the next).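

With methoxy as the third group on this aromatic carbon, the 4-nitrophenyl to 4-methoxyphenyl exchange gives a number 1 percentage points higher from compound 2 to compound 4 (within the scatter) in this assay and the read-out stays in the same narrow band. Putting methoxy in place of hydrogen gives a number 8 percentage points higher from compound 3 to compound 4 (within the scatter) and likewise separates nothing, so nitro, hydrogen and methoxy at this position cannot be told apart by this read-out in compound 2, compound 3 and compound 4. No other measurement bears on this result.

Still open, from the compounds shown here alone, is whether any group on this aromatic carbon, such as an amine or a carboxylic acid, would move growth inhibition beyond the scatter. Also open, going by these compounds, is whether a change elsewhere on the shared core, such as a longer chain, would do so.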